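A few compounds are considered here, and "the series" means these few. Any claim that something is new, unique, unknown or untested is made for them only; others in the source may bear on it.

Measured in a functional assay on HCT-116 cells (Homo sapiens) for antiproliferative activity, with a stated time of 4 h; a lower number here means a stronger inhibitor, a higher number a weaker inhibitor:
- compound 1 `O=C1NC(=O)c2c1c1c(O)cccc1c1[nH]c3ccccc3c21`: 17500 nM
- compound 2 `Cc1ccc2[nH]c3c4c(=O)ccc(=O)c4c4c(=O)[nH]c(=O)c4c3c2c1`: 700 nM

Compound 1 stands at the weak end of this small set. Compound 1, at 17500 nM, carries the higher of the two numbers, and compound 2 lies lower by more than the scatter.

Compound 3 `CC(C)(C)C(=O)Oc1ccc(O)c2c3c(c4c5ccccc5[nH]c4c12)C(=O)NC3=O` keeps the core of compound 1 and differs in one place: ((tert-butyl)carbonyl)oxy in place of hydrogen on an aromatic carbon. The ((tert-butyl)carbonyl)oxy sits on an aromatic carbon of a six-membered aromatic ring of carbon only, para to a hydroxy group.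

Among the measured compounds shown here, no measured pair isolates a change of this kind, so the data offer little direct guidance. For the measured compounds named here, the only pointer is that compound 2, at 700 nM, shows lower numbers occur in this set. A move to a lower number in this assay, beyond the scatter but short of compound 2, is therefore a tentative expectation. The expected size is a 5.8-fold lower number from compound 1 to compound 3 (0.77 log units; beyond the scatter). For compound 3 the estimated value is 3000 nM, with an expected range of 500 nM to 15000 nM.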

Compound 3, half-maximal inhibitory concentration: 8760 nM
Estimate against measurement, compound 3: 2.9-fold (0.47 log units) below, within the range that was stated.
By their numbers in this assay, from the lowest: compound 2; then compounds 3 and 1 (each within the scatter of the next).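

In this assay, ((tert-butyl)carbonyl)oxy in place of hydrogen on this aromatic carbon, para to a hydroxy group, gives a 2.0-fold lower number from compound 1 to compound 3 (0.30 log units; within the scatter). Among the compounds shown here, this is the first readable step, and it shows that this position of the core of compound 1 can carry a group of this size, with no ring and no hydrogen-bond donor, without a change in the antiproliferative read-out that exceeds the scatter. No supporting measurement accompanies the step, so the result stands as an observation on this one pair without an explanation.

The compounds shown leave open whether a smaller acetyloxy group, a free amine or a carboxylic acid on this same aromatic carbon would move the number beyond the scatter. They also leave open whether ((tert-butyl)carbonyl)oxy on another aromatic carbon of the shared core, or in place of the hydroxy group itself, would give a step of similar size.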